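A few compounds are considered here, and "the series" means these few. Any claim that something is new, unique, unknown or untested is made for them only; others in the source may bear on it.

Measured in a functional assay on HCT-116 cells (Homo sapiens), read by MTT assay, with a stated time of 72 h; on this read-out higher numbers stand for weaker inhibition and lower numbers for stronger inhibition:
- compound 1 `CN(C)c1ncnc2c1c(-c1ccsc1)cn2[C@@H]1O[C@H](CO)[C@@H](O)[C@H]1O`: > 20000 nM (a limit)
- compound 2 `O=c1[nH]cnc2c1c(-c1ccccc1)cn2[C@@H]1O[C@H](CO)[C@@H](O)[C@H]1O`: > 20000 nM (a limit)
- compound 3 `O=c1[nH]cnc2c1c(-c1cc3ccccc3o1)cn2[C@@H]1O[C@H](CO)[C@@H](O)[C@H]1O`: > 20000 nM (a limit)

Compound 2 has no numerical value on this read-out, only the limit > 20000 nM. The other two compounds offer no numerical reference either, and the whole set sits at the limit of > 20000 nM in this assay, at which 3 of the 3 values shown sit.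

The next compound is compound 4 `Nc1nc2c(c(-c3ccccc3)cn2[C@@H]2O[C@H](CO)[C@@H](O)[C@H]2O)c(=O)[nH]1`, which differs from compound 2 by amino in place of hydrogen on an aromatic carbon. The amino group sits on an aromatic carbon between two ring nitrogen atoms. Going by the values given here, no measured step covers this change. The nearest one, a step that the two limits leave unreadable from compound 2 to compound 3, is a change at a different place and gives no size to carry over. A move in either direction therefore has no support from the data, and no step beyond the scatter is expected. The most likely outcome is another limit, as the series has given nothing else so far, though a number close to the limit remains possible. For compound 4 the expected value is 25000 nM. The estimated range for compound 4 runs from 10000 nM to 60000 nM. The estimate corresponds to an expected step that the limit leaves unreadable from compound 2 to compound 4.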

Compound 4, half-maximal inhibitory concentration: > 20000 nM
Compound 4 ended at the assay's limit (the forecaster's own chance of this, stated with the estimate: 85%); the middle value does not contradict the limit.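

In this assay compound 4 gives > 20000 nM, a limit and not a number. With compound 2 also at a limit, no step can be read for amino in place of hydrogen on an aromatic carbon. The compounds shown leave open whether any change on the shared core gives a numerical value in this read-out: the limit of > 20000 nM in this assay, at which 4 of the 4 values shown sit.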